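Shortening the Ester Chain of an Adenine Hydroxy Ester

A few compounds are considered here, and "the series" means these few. Any claim that something is new, unique, unknown or untested is made for them only; others in the source may bear on it.

Compound 1 `CCCCOC(=O)C(O)Cn1cnc2c(N)ncnc21` gives 200 ug/mL in a functional assay on PRK cells (Oryctolagus cuniculus) for cytotoxicity; a higher number here means that more compound is tolerated, a lower number that less compound is tolerated.
Compound 2 `COCCOC(=O)C(O)Cn1cnc2c(N)ncnc21` gives only a limit of the assay in this assay, > 400 ug/mL.
Compound 3 `CC(C)COC(=O)C(O)Cn1cnc2c(N)ncnc21` likewise gives only a limit of the assay in this assay, > 400 ug/mL.

Compound 3 therefore stands at the upper edge of what this series has shown: its value is a limit and not a number, and (the limit of > 400 ug/mL in this assay, at which 2 of the 3 values shown sit). The step to compound 4 `CCOC(=O)C(O)Cn1cnc2c(N)ncnc21` is methyl in place of isopropyl on a saturated chain carbon bound to an oxygen next to a carbonyl group.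

For the measured compounds named here, two measured steps bear on this change. Both start from compound 1, whose ester carries an unbranched chain, and both reach a limit: an at least 2.0-fold higher number from compound 1 to compound 2 (0.30 log units; that floor lies within the scatter) and an at least 2.0-fold higher number from compound 1 to compound 3 (0.30 log units; that floor lies within the scatter). The step between compound 2 and compound 3 is a step that the two limits leave unreadable from compound 2 to compound 3. Every departure from compound 1 that has been measured has moved the number up to the limit or beyond, and the move to compound 4 is a further shortening of the ester chain rather than a return toward compound 1.

Compound 4 is accordingly expected to sit at or beyond the same limit, which means an estimated step of a number no higher from compound 3 to compound 4 (the limit leaves the size open). The estimate for compound 4 in this assay is 400 ug/mL, with a range from 200 ug/mL to 800 ug/mL.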

Compound 4, minimum cytotoxic concentration: > 400 ug/mL
Compound 4 ended at the assay's limit; the forecaster's own chance of this, stated with the estimate: 60%; the middle value lies on the limit itself.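

In this assay compound 4 gives > 400 ug/mL, which is a limit of the assay and not a number, so methyl in place of isopropyl on a saturated chain carbon bound to an oxygen next to a carbonyl group did not bring the read-out down to a measurable value. The ethoxy ester of compound 4 also gives a third departure from compound 1, with an at least 2.0-fold higher number from compound 1 to compound 4 (0.30 log units; that floor lies within the scatter), and so far no compound shown other than compound 1 has given a number rather than a limit. The steps among compound 2, compound 3 and compound 4 cannot be read, and these three now share a single limit: the limit of > 400 ug/mL in this assay, at which 3 of the 4 values shown sit.

Going by these compounds, how far beyond that limit compound 2, compound 3 and compound 4 lie remains open, so no order among them can be given. The compounds shown also do not tell whether a chain longer than that of compound 1, which gives 200 ug/mL, would lower the number further, or how an amine on the ester chain would read.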